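Replacing the ring methyl of compound 1 with a pyridinyl carbonyl

This account rests on a few compounds, and the source may have more. Where it says the series, first, only, none or still open, it means among the compounds named here.

Compound 1 `CCCCNc1nc(N)nc2c1CN(C)CC2`: 0.03 uM
Compound 2 `CCCCNc1nc(N)nc2c1CN(Cc1c(Cl)cccc1Cl)CC2`: 0.14 uM
Compound 3 `CCCCNc1nc(N)nc2c1CN(Cc1ccc(C(C)(C)C)cc1)CC2`: 0.66 uM

In an assay on HEK293 cells for agonist activity at Toll-like receptor 8 (Homo sapiens), read by a luciferase reporter, with a stated time of 6 h (on this read-out higher numbers stand for an effect only at larger amounts of compound and lower numbers for an effect already at smaller amounts), compound 1 gives 0.03 uM, the lowest of the three numbers; compound 2 gives 0.14 uM and compound 3 gives 0.66 uM, both beyond the scatter from compound 1. Compound 4 `CCCCNc1nc(N)nc2c1CN(C(=O)c1ccccn1)CC2` differs from compound 1 in one place: (pyridin-2-yl)carbonyl in place of methyl on an amine nitrogen in a ring. Among the measured compounds shown here, the only step that bears on it is a 4.7-fold higher number from compound 1 to compound 2 (0.67 log units; beyond the scatter), where a larger group on the same part of the shared core raised the number modestly; compound 3, also carrying a larger group there, shows a still higher number than compound 1. The change to compound 4 is of similar size and is therefore expected to raise the number in this assay by a modest step, a 6.7-fold higher number from compound 1 to compound 4 (0.82 log units; beyond the scatter). Compound 4 is expected to give about 0.2 uM in this assay, within 0.05 uM to 1 uM.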

Compound 4, minimum effective concentration: 2.9 uM
The estimate for compound 4 lay 15-fold (1.16 log units) below the measured number; the measured number lies above the stated range.
By their numbers in this assay, from the lowest: compound 1; then compound 2; then compound 3; then compound 4.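

The (pyridin-2-yl)carbonyl group brought a 97-fold higher number from compound 1 to compound 4 (1.99 log units; beyond the scatter) in this assay and so far exceeds a 4.7-fold higher number from compound 1 to compound 2 (0.67 log units; beyond the scatter) at the same amine nitrogen in a ring. This shows that the number at this position depends strongly on which large group enters, and not on size alone, with compound 4 now the highest of the four. Nothing measured here accounts for this step. The compounds shown leave open whether the carbonyl or the pyridine ring drives the rise; an acetyl group or a pyridin-2-ylmethyl group on this nitrogen would separate the two.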